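A few compounds are considered here, and "the series" means these few. Any claim that something is new, unique, unknown or untested is made for them only; others in the source may bear on it.

Measured compounds:
compound 1 `COc1ccc2nc(C)cc(OCC(=O)Nc3ccccc3)c2c1` — 39800 nM in a toxicity assay on HepG2 cells (Homo sapiens) for inhibition, read by CellTiter-Glo, with a stated time of 48 h; a lower number here means a stronger inhibitor, a higher number a weaker inhibitor
compound 2 `COc1ccc2nc(C)cc(OCC(=O)Nc3noc(C)c3C)c2c1` — > 100000 nM in this assay, a limit of the assay rather than a number

Within the data shown here, compound 1 supplies the only number in this assay; the one other value recorded is a limit. Compound 3 `COc1ccc2nc(C)cc(OCC(=O)Nc3ccc(S(=O)(=O)Nc4cc(C)on4)cc3)c2c1` differs from compound 1 by (5-methyl-1,2-oxazol-3-yl)sulfamoyl in place of hydrogen on an aromatic carbon. Among the measured compounds shown here, the single measured step does not cover this change: it swapped the ring on the amide-type nitrogen, an at least 2.5-fold higher number from compound 1 to compound 2 (0.40 log units; beyond the scatter), with the weaker compound sitting at the limit of > 100000 nM in this assay, at which 1 of the 2 values shown sits. Compound 3 keeps the phenyl of compound 1 and adds the sulfamoyl group to it, so that step bears only loosely on the present change. Given that compound 1 is already weak at 39800 nM, a step in the weakening direction or none beyond the scatter is expected, a 1.4-fold higher number from compound 1 to compound 3 (0.14 log units; within the scatter). Compound 3 is therefore estimated at 55000 nM, range 15000 nM to 200000 nM, with a fair chance that only a limit is reported.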

Compound 3, half-maximal inhibitory concentration: > 100000 nM
Compound 3: only a limit was reported; the forecaster's own chance of this, stated with the estimate: 35%; middle value at least 1.8-fold (0.25 log units) from the limit.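

Substitution on the phenyl of compound 1 is a new kind of change in this series: (5-methyl-1,2-oxazol-3-yl)sulfamoyl in place of hydrogen on this aromatic carbon, para to a large group, brings an at least 2.5-fold higher number from compound 1 to compound 3 (0.40 log units; beyond the scatter) in this assay. The phenyl therefore need not be exchanged for the series to reach the limit, since adding this group to it has that outcome, as did the ring swap on the amide-type nitrogen in an at least 2.5-fold higher number from compound 1 to compound 2 (0.40 log units; beyond the scatter). Compound 1 remains the only compound with a number, so the full size of the new step stays unknown: the limit of > 100000 nM in this assay, at which 2 of the 3 values shown sit.

As far as these compounds go, whether a smaller group at this position, such as an amine or a carboxylic acid, also shifts the number beyond the scatter remains open. Also open, from the compounds shown here alone, is whether a plain sulfamoyl group, without the 5-methyl-1,2-oxazol-3-yl ring, would produce the same step.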